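The source may hold more compounds than are shown below. What is called first, only, known or untested is meant among the compounds shown, and "the series" means these compounds.

Measured so far:
- compound 1, `CCCC(=O)N1CC2CC(C1)N2`, 120%
- compound 2, `CC(C)C(=O)N1CC2CC(C1)N2`, 86%
- compound 3, `O=C(C1CCCC1)N1CC2CC(C1)N2`, 48%

In an assay on SH-EP1 cells for agonist activity at Neuronal acetylcholine receptor; alpha4/beta2 (Homo sapiens), read by FLIPR and calcium flux (on this read-out higher numbers stand for larger maximal responses and lower numbers for smaller maximal responses), compound 2 stands second highest of the three numbers. Its nearest neighbour is compound 1, which gives 120%; the step of a number 34 percentage points lower from compound 1 to compound 2 (beyond the scatter) lies beyond the scatter. Furthest from it is compound 3, which gives 48%, a number well below compound 2.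

The unmeasured compound 4, `O=C([C@@H]1C[C@@H]1F)N1CC2CC(C1)N2`, differs from compound 2 in a single place: 2-fluorocyclopropyl in place of isopropyl on a carbonyl carbon. Among the measured compounds shown here, only one measured step bears on this change, the one from compound 1 to compound 2, in which a branched group replaced a straight chain on the same carbonyl carbon and the maximal response fell by a number 34 percentage points lower from compound 1 to compound 2 (beyond the scatter). The values of compound 2 and compound 3 show that a larger ring on that carbon goes with a still lower number. A small fluorinated ring is not represented among the measured compounds, so the direction of the step is uncertain. Compound 4 is therefore expected to give 70%, within a range of 40% to 105%, which means an expected step of a number 16 percentage points lower from compound 2 to compound 4 (beyond the scatter) in this assay.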

Compound 4, largest response reached (Emax), in percent of the reference or control that the assay uses: 120%
Compound 4: the middle estimate sits 50 percentage points below what was measured, and the stated range ends below it.
By their numbers in this assay, from the lowest: compound 3; then compound 2; then compounds 1 and 4 (each within the scatter of the next).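

In this assay the change to 2-fluorocyclopropyl on this carbonyl carbon gives a number 34 percentage points higher from compound 2 to compound 4 (beyond the scatter) and so shows that replacing the straight chain need not lower the number. Set against the propyl group of compound 1, the same group gives no change at the digits printed from compound 1 to compound 4 (within the scatter) and the two compounds share the top of this set. A ring on the carbonyl carbon is not tied to a low number either: compound 3 gives 48% while compound 4, also carrying a ring there, gives 120% on the same read-out.

The compounds shown leave open whether the fluorine or the three-membered ring carries the rise, which plain cyclopropyl on the same carbon would separate, and whether the other stereoisomers of 2-fluorocyclopropyl behave alike. No measurement offered here accounts for the step.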